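Replacing Dimethylphenyl with Dibromophenyl: Expected Cytotoxicity

The compounds below may be only part of what the source reports. "The series", "measured", "known", "first", "only" and "open" are said of these compounds alone.

Of the compounds shown here, three from one series have been tested in an ADME assay on Huh7.5.1 cells (Homo sapiens) for cytotoxicity, read by ATP content, with a stated time of 48 h; on this read-out lower numbers stand for higher toxicity in this test and higher numbers for lower toxicity in this test. Compound 1 `Cc1ccc(C)c(-c2nc(CN3CCC(C(=O)NCCCN4C[C@H](C)C[C@H](C)C4)CC3)c(C)o2)c1` gives 4070 nM in this assay, the second highest of the three numbers. Compound 2 `CC[C@@H]1C[C@H](CC)CN(CCCNC(=O)C2CCN(Cc3nc(-c4ccccc4C)oc3C)CC2)C1` gives 3470 nM, which lies within the scatter of the number for compound 1, so the two cannot be told apart. Compound 3 `CC[C@@H]1C[C@H](CC)CN(CCCNC(=O)C2CCN(Cc3nc(-c4c(F)cccc4F)oc3C)CC2)C1` gives 12600 nM, and this one stands clearly apart from the others.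

Compound 4 `Cc1oc(-c2c(Br)cccc2Br)nc1CN1CCC(C(=O)NCCCN2C[C@H](C)C[C@H](C)C2)CC1` has not yet been measured in this assay. It differs from compound 1 in one place: 2,6-dibromophenyl in place of 2,5-dimethylphenyl on an aromatic carbon. Among the compounds with values here, the only measured step that bears on this change is a 3.6-fold higher number from compound 2 to compound 3 (0.56 log units; beyond the scatter), where 2,6-difluorophenyl took the place of 2-methylphenyl on the same aromatic carbon and the number rose. Within the data shown here, the change from compound 1 to compound 4 likewise puts two substituents on the phenyl ring in place of methyl groups, so the step is expected to go in the same direction, toward a higher number, though its size is uncertain with only one such step among the measurements. For compound 4 the expected step is a 1.8-fold higher number from compound 1 to compound 4 (0.27 log units; within the scatter). Compound 4 is therefore estimated at 7500 nM, with a likely range from 3000 nM to 18000 nM.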

Compound 4, half-maximal cytotoxic concentration: 6500 nM
Beside the measured number, compound 4's estimate is 1.2-fold (0.06 log units) above it; low and high end bracket the measured number.
By their numbers in this assay, from the lowest: compounds 2, 1, 4 and 3 (each within the scatter of the next, the first and the last beyond it).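

In this assay, a 1.6-fold higher number from compound 1 to compound 4 (0.20 log units; within the scatter) means that compound 1 and compound 4 cannot be told apart, even though two bromine atoms replace the two methyl carbons of the ring while the group keeps the same count of heavy atoms. The earlier step at this aromatic carbon, a 3.6-fold higher number from compound 2 to compound 3 (0.56 log units; beyond the scatter), lay beyond the scatter, so among these compounds, putting two halogens on the phenyl ring does not always produce a clear rise in the number; compound 4 is the case that goes against that pattern. No measurement here explains why one halogen swap stands out from the scatter and the other does not.

The two halogen steps also start from different parent groups and sit on cores with different rings at the far end of the chain, so 2,6-difluorophenyl on the core of compound 1 would be needed to compare the two halogens directly. As far as these compounds go, it also remains open how this position responds to a phenyl ring carrying an amine or a carboxylic acid, or to an unsubstituted phenyl.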